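From Methoxy to Nitro: Expected Paw Edema Inhibition

The source may hold more compounds than are shown below. What is called first, only, known or untested is meant among the compounds shown, and "the series" means these compounds.

Of the compounds shown here, two that share one core have been tested in a functional assay on the whole organism (strain albino) for inhibition, with Rattus norvegicus as the target, read by paw edema, with a stated time of 1 h, at a dose of 20 mmol/kg by the intraperitoneal route; on this read-out higher numbers stand for more inhibition at the one dose given (going by the name of the read-out) and lower numbers for less inhibition. In this assay compound 1 `CCOC(=O)C(=O)NC1=C(C#N)C2C(N3CCCC3)CCCCN2C(=O)N1c1ccccc1` gives 71.2%, while compound 2 `COc1ccc(/C=N/C2=C(C#N)C3C(N4CCCC4)CCCCN3C(=O)N2c2ccccc2)cc1` gives 59.1%. Of these two numbers compound 2 stands lowest; the drop a number 12.1 percentage points lower from compound 1 to compound 2 (beyond the scatter) lies beyond the scatter. Compound 3 `N#CC1=C(/N=C/c2ccc([N+](=O)[O-])cc2)N(c2ccccc2)C(=O)N2CCCCC(N3CCCC3)C12` has not yet been measured. It differs from compound 2 by nitro in place of methoxy on an aromatic carbon, so that a 4-methoxyphenyl becomes a 4-nitrophenyl. Within the data shown here, the one measured step exchanged a whole ring-free group for a ring-bearing group on the double-bonded ring carbon, a different kind of change, and no measured pair shows what a nitro-for-methoxy exchange does. With nothing pointing either way, the expected step of a number 0.1 percentage points lower from compound 2 to compound 3 (within the scatter) is none beyond the scatter. Compound 3 is therefore estimated at 59%, within a likely range from 45% to 73%.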

Compound 3, a percentage reported as inhibition, in the whole organism at one dose (the size of the read-out at that dose, not a potency): 66%
Compound 3: the middle estimate sits 7 percentage points below what was measured, within the range that was stated.
By their numbers in this assay, from the lowest: compounds 2, 3 and 1 (each within the scatter of the next, the first and the last beyond it).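

In this assay, among these compounds, nitro in place of methoxy on this aromatic carbon gives a number 6.9 percentage points higher from compound 2 to compound 3 (within the scatter), so the first measured exchange at this position does not separate the two compounds. On the double-bonded ring carbon, the 4-nitrophenyl-bearing group in place of the ring-free group gives a number 5.2 percentage points lower from compound 1 to compound 3 (within the scatter), whereas the 4-methoxyphenyl-bearing group gave a number 12.1 percentage points lower from compound 1 to compound 2 (beyond the scatter), so a ring-bearing group there does not always set a compound apart from compound 1, with compound 2 as the case that does differ. Nothing measured here offers an explanation for these numbers.

On these data alone, it remains open whether an amine or a carboxylic acid on the same aromatic carbon would also stay within the scatter of compound 2. A single dose also leaves open how these compounds would compare at other doses.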